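Chloro for fluoro: what compound 4 may show

The source may hold more compounds than are shown below. What is called first, only, known or untested is meant among the compounds shown, and "the series" means these compounds.

Measured in an ADME assay on HepG2 cells (Homo sapiens) for cytotoxicity, read by neutral red uptake, with a stated time of 24 h (a lower number here means that less compound is tolerated, a higher number that more compound is tolerated), so far:
Compound 1 `Clc1cccc(C(Nc2ccnc3cc(Cl)ccc23)c2ccc(CN3CCCC3)cc2)c1` gives 31 uM
Compound 2 `Fc1cc(C(Nc2ccnc3cc(C(F)(F)F)ccc23)c2ccc(Cl)cc2)ccc1CN1CCCC1` gives 19 uM
Compound 3 `Fc1cc(C(Nc2ccnc3cc(Cl)ccc23)c2ccc(Cl)cc2)ccc1CN1CCCC1` gives 12 uM

In this assay compound 3 reads 12 uM and so lies within the scatter of compound 2, while its number is lower than that of compound 1 by more than the scatter. The change to compound 4 `Clc1ccc(C(Nc2ccnc3cc(Cl)ccc23)c2ccc(CN3CCCC3)c(Cl)c2)cc1` is chloro in place of fluoro on an aromatic carbon and it sits on an aromatic carbon of the six-membered ring of carbon only, ortho to a (pyrrolidin-1-yl)methyl group. Going by the values given here, only one measured step bears on this, and only loosely. The step of a 1.6-fold lower number from compound 2 to compound 3 (0.20 log units; within the scatter) also brings in chloro on an aromatic carbon, but in place of trifluoromethyl and at another place in the molecule. Among the compounds with values here, no measured pair exchanges fluoro for chloro. With that single small step as a guide, a step of a 1.1-fold lower number from compound 3 to compound 4 (0.04 log units; within the scatter) is expected, which would stay within the scatter. Compound 4 is estimated at 11 uM with an expected range from 5 uM to 24 uM in this series.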

Compound 4, half-maximal toxic concentration: 4 uM
Beside the measured number, compound 4's estimate is 2.8-fold (0.44 log units) above it; measured number below the stated range.
By their numbers in this assay, from the lowest: compound 4; then compounds 3, 2 and 1 (each within the scatter of the next, the first and the last beyond it).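

In this assay, going by these compounds alone, exchanging fluoro for chloro ortho to a (pyrrolidin-1-yl)methyl group gives a 3.0-fold lower number from compound 3 to compound 4 (0.48 log units; beyond the scatter), whereas the only earlier step, a 1.6-fold lower number from compound 2 to compound 3 (0.20 log units; within the scatter), involved a change elsewhere in the molecule. This shows that the number can respond to a change at this position, even though one heavy atom replaces one heavy atom and the counts of hydrogen-bond donors, hydrogen-bond acceptors and net charge stay the same. Nothing available here accounts for the shift.

The compounds shown leave open how a methyl, a methoxy or a nitrile at this position would read in this assay. They also leave open whether the same exchange of fluoro for chloro would shift the number similarly in compound 2, which carries trifluoromethyl where compound 3 carries chloro.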